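Three configurations of one amide, one stability read-out

The source may hold more compounds than are shown below. What is called first, only, known or untested is meant among the compounds shown, and "the series" means these compounds.

Compound 1, `O=C(N[C@H](CO)C(=O)O)[C@@H]1C[C@@H](O)CN1`: > 12 h, a limit
Compound 2, `O=C(O)[C@H](CO)NC(=O)[C@H]1C[C@@H](O)CN1`: > 12 h, a limit

In a physicochemical assay for metabolic stability, read by HPLC, in phosphate buffer, with a stated time of 12 h, at pH 7.2 (a lower number here means that the compound disappears faster, a higher number that the compound lasts longer), compound 1 gives only a limit, > 12 h. Compound 2 in this assay likewise reaches only a limit, > 12 h. The step that the two limits leave unreadable from compound 1 to compound 2 cannot be sized, because of the limit of > 12 h in this assay, at which 2 of the 2 values shown sit; the two compounds are related because of the fact that compounds 1 and 2 differ only in the configuration as drawn.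

Compound 3, `O=C(O)[C@@H](CO)NC(=O)[C@H]1C[C@H](O)CN1`, has not yet been measured. It differs from compound 1 in this way: the two compounds have the same atoms and bonds and differ only in configuration as drawn: 2 of 3 stereo elements differ; a stereocentre at a saturated ring carbon is drawn S in compound 1 and R in compound 3; a stereocentre at a saturated ring carbon is drawn R in compound 1 and S in compound 3. For the measured compounds named here, the only measured step that resembles this one is the change of configuration from compound 1 to compound 2, and its size is unreadable. Since both measured isomers sit at the limit, compound 3 is expected to show no readable change, a step that the limit leaves unreadable from compound 1 to compound 3. The estimate for compound 3 is therefore 14 h, within 8 h to 30 h, most likely reported again as a limit.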

Compound 3, half-life: > 12 h
Compound 3 ended at the assay's limit; the forecaster's own chance of this, stated with the estimate: 85%; the middle value is on the limit's open side.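

No step among compound 1, compound 2 and compound 3 can be read in this assay, so none of the three can be ranked: the limit of > 12 h in this assay, at which 3 of the 3 values shown sit.

The compounds shown leave open how long each one actually lasts, and whether changing the drawn configuration shifts its half-life at all.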